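This account rests on a few compounds, and the source may have more. Where it says the series, first, only, none or still open, it means among the compounds named here.

Measured compounds, each with its value in an assay on HEK293 cells for positive allosteric modulation of metabotropic glutamate receptor 5 (Homo sapiens), read by FLIPR, with a stated time of 1 h; on this read-out higher numbers stand for an effect only at larger amounts of compound and lower numbers for an effect already at smaller amounts:

Compound 1 `CC(C)CN1CCc2nc(C#Cc3ccccc3)sc2C1`: > 10000 nM; this value is a limit of the assay.
Compound 2 `C(#Cc1nc2c(s1)CN(C1CCCCC1)CC2)c1ccccc1`: > 10000 nM; this value is a limit of the assay.
Compound 3 `O=C(C1CCC1)N1CCc2nc(C#Cc3ccccc3)sc2C1`: > 10000 nM; this value is a limit of the assay.

Compound 3 therefore does not stand at a number at all: in this assay it reaches only the limit, and the same holds for compound 1 and compound 2, as the limit of > 10000 nM in this assay, at which 3 of the 3 values shown sit, states. The steps among them, a step that the two limits leave unreadable from compound 1 to compound 2, a step that the two limits leave unreadable from compound 1 to compound 3 and a step that the two limits leave unreadable from compound 2 to compound 3, are all unreadable for that reason, and none tells how the group on the ring nitrogen moves the read-out.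

Compound 4 `O=C(C1CCC(F)(F)CC1)N1CCc2nc(C#Cc3ccccc3)sc2C1` differs from compound 3 in one place: 4,4-difluorocyclohexyl in place of cyclobutyl on a carbonyl carbon. Going by the values given here, no measured step bears on this change, and no step reaches a number from which a direction or size could be taken. The expectation for compound 4 in this assay is therefore a step of an at least 1.2-fold lower number from compound 3 to compound 4 (0.09 log units; that floor lies within the scatter) that carries little weight, and compound 4 is estimated at 8000 nM, within 2000 nM to 30000 nM, with a real chance that only a limit is reported again.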

Compound 4, half-maximal effective concentration: 70 nM
For compound 4 the middle estimate is 110-fold (2.06 log units) above the measured one; measured number below the stated range.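

In this assay, going by these compounds alone, putting 4,4-difluorocyclohexyl in place of cyclobutyl on the carbonyl carbon gives an at least 140-fold lower number from compound 3 to compound 4 (2.15 log units; beyond the scatter), the first step in this set that can be read at all. The value of compound 3, > 10000 nM, is a limit of the assay. The shared core can therefore give a measurable effect, and the group on this carbonyl carbon can carry it from a limit to a real number, although most of the set still sits at that limit: the limit of > 10000 nM in this assay, at which 3 of the 4 values shown sit.

Still open, going by these compounds, is whether the gain comes with the two fluorine atoms or with the larger ring, a question that a plain cyclohexyl on the same carbonyl carbon would help to separate. On these data alone, the steps among compound 1, compound 2 and compound 3 cannot be read, and how a carbonyl-free 4,4-difluorocyclohexyl on the ring nitrogen would behave also remains unknown.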